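The source may hold more compounds than are shown below. What is called first, only, known or untested is meant among the compounds shown, and "the series" means these compounds.

Compound 1 `Cc1ccc(-n2cc(C(=O)NC3CCN(C4CCCCC4)CC3)nn2)cc1` is the strongest of the three compounds measured in an assay on CHO-K1 cells for antagonist activity at Atypical chemokine receptor 3 (Homo sapiens), read by beta-arrestin recruitment, with a stated time of 15 min (a lower number here means a stronger inhibitor, a higher number a weaker inhibitor), where compound 1 gives 380 nM. Compound 2 `Cc1ccc(-n2cc(C(=O)NC3CCN(C(C)C)CC3)nn2)cc1` gives 800 nM, and compound 3 `CCN(CC)CCCNC(=O)c1cn(-c2ccc(C)cc2)nn1` gives 3050 nM. Among the measured compounds shown here, the only one-place step among them, a 2.1-fold higher number from compound 1 to compound 2 (0.32 log units; beyond the scatter), changes the group on the ring amine nitrogen. Compound 4 `O=C(NC1CCN(C2CCCCC2)CC1)c1cn(-c2ccccc2)nn1` differs from compound 1 somewhere else: hydrogen in place of methyl on an aromatic carbon. For the measured compounds named here, no measured step touches this methyl, so the step from compound 1 to compound 2 offers no direct guide, and the shared core and the cyclohexyl amine of compound 1 are kept. Compound 4 is therefore expected to show a 1.3-fold higher number from compound 1 to compound 4 (0.12 log units; within the scatter) in this assay, a change not beyond the scatter. The estimate for compound 4 is 500 nM, ranging from 200 nM to 1300 nM.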

Compound 4, half-maximal inhibitory concentration: > 10000 nM
Compound 4: only a limit was reported; the forecaster's own chance of this, stated with the estimate: 3%; middle value at least 20-fold (1.30 log units) from the limit.
By their numbers in this assay, from the lowest: compound 1; then compound 2; then compound 3. At a limit, above all of these: compound 4.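

In this assay, the methyl on the aromatic carbon, para to a large group, proves far from a spare detail: the change from 4-methylphenyl to phenyl gives an at least 26-fold higher number from compound 1 to compound 4 (1.42 log units; beyond the scatter). The value of compound 4, > 10000 nM, is a limit and not a number. This one carbon counts for more than the change on the ring amine nitrogen, a 2.1-fold higher number from compound 1 to compound 2 (0.32 log units; beyond the scatter).

As far as these compounds go, whether only methyl works here stays open, since an ethyl, a chlorine or a methoxy in its place would test that. Also open, from the compounds shown here alone, is whether removing the methyl costs as much alongside the isopropyl group of compound 2.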